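A few compounds are considered here, and "the series" means these few. Any claim that something is new, unique, unknown or untested is made for them only; others in the source may bear on it.

Compound 2 `CC(C)=CCOc1c(C)c(C)c2c(c1C)CCC(C)(COc1ccc(/C=C3\SC(=O)NC3=O)cc1)O2` gives 21% in a functional assay on MCF7 cells (Homo sapiens), tested at 5 uM (a higher number here means a weaker effect of the compound at the concentration tested, a lower number a stronger effect), the lowest of the two numbers shown. Compound 1 `CC(C)=CCOc1c(C)c(C)c2c(c1C)CCC(C)(COc1ccc(/C=C3\SC(=O)NC3=O)cc1C)O2` gives 56% in this assay. Compound 3 `CC(C)=CCOc1c(C)c(C)c2c(c1C)CCC(C)(COc1ccc(/C=C3\SC(=O)NC3=O)cc1Br)O2` differs from compound 2 by bromo in place of hydrogen on an aromatic carbon. Going by the values given here, the one step that bears on this is a number 35 percentage points lower from compound 1 to compound 2 (beyond the scatter), a large step when a methyl on an aromatic carbon gave way to hydrogen. Among the compounds with values here, with bromo now taking the place that hydrogen held in compound 2, the number is expected to move back upward in this assay by a step of comparable size, though no measured pair shows how closely bromo tracks methyl, so the range stays wide. The estimate for compound 3 is 45%, from 25% to 68%, meaning a number 24 percentage points higher from compound 2 to compound 3 (beyond the scatter).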

Compound 3, a percentage reported as activity, at one concentration (the size of the read-out at that concentration, not a potency): 84%
Beside the measured number, compound 3's estimate is 39 percentage points below it, and the stated range ends below it.
By their numbers in this assay, from the lowest: compound 2; then compound 1; then compound 3.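

In this assay, methyl and bromo do not act alike on this aromatic carbon: bromo in place of hydrogen gives a number 63 percentage points higher from compound 2 to compound 3 (beyond the scatter) and bromo in place of methyl gives a number 28 percentage points higher from compound 1 to compound 3 (beyond the scatter) in the same direction. Among these three compounds, hydrogen carries the lowest number and bromo the highest, so the identity of the group matters and not only whether one is present. Nothing measured here accounts for the gap between bromo and methyl. Still open, from the compounds shown here alone, is whether any group on this carbon gives a number as low as hydrogen does. Fluoro, chloro, methoxy or a carboxylic acid would test this.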